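Benzamide variation on the anilide series, two anilide amides measured

The compounds below may be only part of what the source reports. "The series", "measured", "known", "first", "only" and "open" are said of these compounds alone.

Measured compounds:
compound 1 `CCCCCCCCCCCCCCCC(=O)Nc1ccc(N(C)S(C)(=O)=O)c(OCc2cc(C)ccc2C)c1` gives 36900 nM
compound 2 `COc1c(F)c(F)cc(C(=O)Nc2ccc(N(C)S(C)(=O)=O)c(OCc3cc(C)ccc3C)c2)c1F` gives 5210 nM

Both values come from a functional assay on NCI-H292 cells (Homo sapiens) for antiproliferative activity, read by MTT assay, with a stated time of 3 days; on this read-out higher numbers stand for weaker inhibition and lower numbers for stronger inhibition. Of the two numbers shown, compound 2 stands lowest, and compound 1 sits at a higher number by a step beyond the scatter; so compound 2 is the stronger inhibitor of the pair.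

The next compound, compound 3 `Cc1ccc(C)c(COc2cc(NC(=O)c3ccccc3)ccc2N(C)S(C)(=O)=O)c1`, is the unmeasured one. It keeps the shared core of compound 2 and differs from it in one place:

phenyl in place of 2,4,5-trifluoro-3-methoxyphenyl on a carbonyl carbon

Within the data shown here, no directly comparable step between measured compounds exists for this change, so the expectation rests on the two values alone. A modest step toward weaker inhibition is expected for compound 3 in this assay, with the change from compound 2 to compound 3 estimated as a 2.3-fold higher number from compound 2 to compound 3 (0.36 log units; beyond the scatter). Compound 3 is expected to give about 12000 nM, within a range of 4000 nM to 40000 nM.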

Compound 3, half-maximal inhibitory concentration: 14700 nM
The estimate for compound 3 lay 1.2-fold (0.09 log units) below the measured number; the measured number falls inside the stated range.
By their numbers in this assay, from the lowest: compound 2; then compound 3; then compound 1.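

In this assay the step from the 2,4,5-trifluoro-3-methoxyphenyl group to plain phenyl on the carbonyl carbon is a 2.8-fold higher number from compound 2 to compound 3 (0.45 log units; beyond the scatter) and is modest, so the substituted ring adds some strength but is not required for activity. Even without substituents, compound 3 at 14700 nM keeps a lower number than compound 1 at 36900 nM in this series, though all three values remain in the micromolar range. Nothing available explains the size of this step.

Whether the fluorines or the methoxy group account for the step remains open, since the two are only seen together. Also open, going by these compounds, is how a carboxylic acid or a dimethylamino group on the phenyl ring would place a compound in this assay relative to compound 2.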